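One Small Group Exchanged in a Growth Inhibition Series

This account rests on a few compounds, and the source may have more. Where it says the series, first, only, none or still open, it means among the compounds named here.

In a functional assay on MV4-11 cells (Homo sapiens) for inhibition, read by resazurin assay, with a stated time of 72 h (on this read-out higher numbers stand for weaker inhibition of growth and lower numbers for stronger inhibition of growth), compound 1 `COc1ccc(Nc2nccc(-c3sc(SC(C)C)nc3C)n2)c(OC)c1` gives 5670 nM and compound 2 `COc1ccc(Nc2nccc(-c3cn(C)c4ccccc34)n2)c(OC)c1` gives 3410 nM. These two numbers lie within the usual scatter of repeat measurements, so compound 1 stands level with compound 2. Compound 3 `COc1ccc(Nc2nccc(-c3sc(N(C)C)nc3C)n2)c(OC)c1` keeps the core of compound 1 and carries a single change, dimethylamino in place of isopropylsulfanyl on an aromatic carbon. Going by the values given here, no measurement yet shows what an exchange at this place does. Compound 2 differs from compound 1 in a larger part of the structure, and compound 2 still gives 3410 nM, so this smaller exchange is expected to move the number little. The expected step of a 1.6-fold lower number from compound 1 to compound 3 (0.21 log units; within the scatter) points slightly towards stronger inhibition of growth but is not expected to go beyond the scatter. In this assay the estimate for compound 3 is 3500 nM, with an expected range from 1000 nM to 12000 nM.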

Compound 3, concentration for 50% growth inhibition: 170 nM
For compound 3 the middle estimate is 21-fold (1.31 log units) above the measured one, outside the stated range (below it).
By their numbers in this assay, from the lowest: compound 3; then compounds 2 and 1 (each within the scatter of the next).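

Exchanging isopropylsulfanyl for dimethylamino on this aromatic carbon brings a 33-fold lower number from compound 1 to compound 3 (1.52 log units; beyond the scatter) in this assay, so this position strongly affects growth inhibition in this series. The size of the step stands out against how little the two groups differ in the simple counts: neither has a ring or a net charge, both have the same number of hydrogen-bond acceptors, and dimethylamino has just one heavy atom fewer. No measurement given here explains why this exchange has so large an effect.

As far as these compounds go, it remains open whether the gain follows the nitrogen attached to the ring or the two methyl groups it carries; isopropylamino and methylsulfanyl would help separate the two. Larger amines such as morpholine or pyrrolidine leave open how much room for change this position allows.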